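This account rests on a few compounds, and the source may have more. Where it says the series, first, only, none or still open, it means among the compounds named here.

Measured compounds:
compound 1 `O=C(Nc1cccc(-n2cc(-c3ccncc3)c(-c3cc(O)cc(Cl)c3)n2)c1)Nc1ccc(Cl)c(C(F)(F)F)c1` gives 90%
compound 2 `COc1cc(Cl)cc(-c2nn(-c3cccc(NC(=O)Nc4cc(C(F)(F)F)cc(C(F)(F)F)c4)c3)cc2-c2ccncc2)c1` gives 17%

In a functional assay on HCT-15 cells (Homo sapiens) for inhibition, read by sulforhodamine B assay, with a stated time of 48 h, tested at 1 uM (on this read-out lower numbers stand for a stronger effect and higher numbers for a weaker effect at the one concentration tested), compound 2 gives 17%, the lowest of the two numbers, and the nearest value, that of compound 1, lies well beyond the scatter above it; compound 1 and compound 2 differ in more than one place, so only their two values can be compared. Compound 3 `COc1cc(Cl)cc(-c2nn(-c3cccc(NC(=O)Nc4cccc(C(F)(F)F)c4)c3)cc2-c2ccncc2)c1` has not yet been measured. It differs from compound 2 by hydrogen in place of trifluoromethyl on an aromatic carbon, on an aromatic carbon of a six-membered aromatic ring of carbon only, meta to a large group and meta to a trifluoromethyl group. Going by the values given here, no measured pair shows this change on its own. Because compound 2 gives 17% with two trifluoromethyl groups and compound 3 keeps only one, the step from compound 2 to compound 3 is expected to weaken the effect, estimated as a number 28 percentage points higher from compound 2 to compound 3 (beyond the scatter). Compound 3 is therefore expected to give 45%, in a range from 20% to 80%.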

Compound 3, a percentage reported as activity, at one concentration (the size of the read-out at that concentration, not a potency): 57%
Beside the measured number, compound 3's estimate is 12 percentage points below it, within the range that was stated.
By their numbers in this assay, from the lowest: compound 2; then compound 3; then compound 1.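

In this assay, going by these compounds alone, this is the first change that can be read on its own, since compound 1 and compound 2 differ in more than one place. Hydrogen in place of trifluoromethyl on this aromatic carbon, meta to a large group and meta to a trifluoromethyl group, gives a number 40 percentage points higher from compound 2 to compound 3 (beyond the scatter), a clear weakening of the effect. The trifluoromethyl group that remains in compound 3 therefore does not preserve the effect of compound 2, and nothing shown accounts for this loss.

The compounds shown leave open what a nitrile or an amine on this same carbon would give, and so whether the effect depends on trifluoromethyl itself. Going by these compounds, it also remains open whether this step would be of similar size on the core of compound 1.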